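The source may hold more compounds than are shown below. What is called first, only, known or untested is meant among the compounds shown, and "the series" means these compounds.

Measured so far:
compound 1 `CC(C)(C)c1ccc(NC(=O)c2ccc(-c3ncccc3F)cc2)cc1` gives 3 nM in a functional assay for antagonist activity at transient receptor potential cation channel subfamily V member 1 (Homo sapiens), read by FLIPR; on this read-out lower numbers stand for stronger inhibition and higher numbers for weaker inhibition;
compound 2 `CCS(=O)(=O)Nc1cccnc1-c1ccc(C(=O)Nc2ccc(C(C)(C)C)cc2)cc1` gives 49 nM in this assay.

Among the measured compounds shown here, compound 2 stands as the higher of the two numbers, with compound 1 the only neighbour. For the measured compounds named here, the one measured step, a 16-fold higher number from compound 1 to compound 2 (1.21 log units; beyond the scatter), came from putting (ethylsulfonyl)amino in place of fluoro on an aromatic carbon. Compound 3 `CC(C)(C)c1ccc(NC(=O)c2ccc(-c3ncccc3C(=O)O)cc2)cc1` has not yet been measured. It differs from compound 2 by carboxy in place of (ethylsulfonyl)amino on an aromatic carbon. Going by the values given here, the step from compound 1 to compound 2 is the only guide, and it shows that a larger substituent at this position gave a much weaker result than fluoro; the carboxy group is a different kind of substituent, so the carry-over is uncertain. Compound 3 is expected to remain at a weak level, with a step of a 3.1-fold higher number from compound 2 to compound 3 (0.49 log units; beyond the scatter) in this assay that is estimated to be a modest rise. The estimate for compound 3 is 150 nM, with a range from 20 nM to 2000 nM.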

Compound 3, half-maximal inhibitory concentration: > 4000 nM
Compound 3: only a limit was reported; the forecaster's own chance of this, stated with the estimate: 15%; at least 26-fold (1.42 log units) between middle value and limit.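

In this assay, placing carboxy on this aromatic carbon, ortho to a large group and two atoms from the ring nitrogen, gives an at least 81-fold higher number from compound 2 to compound 3 (1.91 log units; beyond the scatter), and measured against fluoro the same change gives an at least 1300-fold higher number from compound 1 to compound 3 (3.12 log units; beyond the scatter). The first two compounds showed only that (ethylsulfonyl)amino reads weaker than fluoro here, whereas carboxy, with 3 heavy atoms against 6, reads weaker still, so among these three groups the larger one is not simply the weaker one. The reading for compound 3 is a limit and not a number, which makes both steps minimum sizes: the limit of > 4000 nM in this assay, at which 1 of the 3 values shown sits.

The compounds shown do not tell whether the loss belongs to the carboxy group itself or would persist in its methyl ester or a primary amide, both of which keep the carbonyl. They also leave open how a small amine or a methyl group would read at this place.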